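Flipping One Double Bond in a Weak Inhibitor

A few compounds are considered here, and "the series" means these few. Any claim that something is new, unique, unknown or untested is made for them only; others in the source may bear on it.

Among the measured compounds shown here, in a functional assay on MCF7 cells (Homo sapiens) for inhibition, read by sulforhodamine B assay, with a stated time of 48 h (a higher number here means a weaker inhibitor, a lower number a stronger inhibitor), compound 1 (`CCNC(=O)Nc1ccc(/C=C\c2cc(OC)c(OC)c(OC)c2)cc1`) gives 21000 nM as the higher of the two numbers so far, while compound 2 (`Cc1cc(C)cc(/C=C\c2ccc(N3CCNC3=O)cc2)c1`) gives 23 nM as the lower one. Compound 3 (`CCNC(=O)Nc1ccc(/C=C/c2cc(OC)c(OC)c(OC)c2)cc1`) has a double bond drawn E where compound 1 has it drawn Z (the two compounds have the same atoms and bonds and differ only in configuration as drawn: 1 of 1 stereo elements differ; a double bond is drawn Z in compound 1 and E in compound 3). For the measured compounds named here, no measured pair yet shows what such a flip does in this assay. With compound 1 already weak at 21000 nM in this test, no change in either direction beyond the scatter is expected. The estimated change is a 1.1-fold lower number from compound 1 to compound 3 (0.02 log units; within the scatter) and remains uncertain. For compound 3, the estimated value is 20000 nM within an expected range of 5000 nM to 80000 nM in this test.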

Compound 3, half-maximal inhibitory concentration: 17000 nM
For compound 3 the middle estimate is 1.2-fold (0.07 log units) above the measured one, within the range that was stated.
By their numbers in this assay, from the lowest: compound 2; then compounds 3 and 1 (each within the scatter of the next).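

In this assay, among the compounds shown here, the flip of the double bond gives a 1.2-fold lower number from compound 1 to compound 3 (0.09 log units; within the scatter), the first reading of this change. The comparison is a clean one, with nothing else in the structure to account for a difference: the fact that compounds 1 and 3 differ only in the configuration as drawn. Compounds 1 and 3 therefore stand level, and with this substitution the configuration of the double bond alone shows no effect.

From the compounds shown here alone, what the same flip does in a far stronger compound, such as compound 2 at 23 nM, stays open. Also open, going by these compounds, is whether an amine or a carboxylic acid in place of the methoxy groups would make the configuration matter.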